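The source may report more compounds than this note shows. Statements on the series, on what has been measured and on what is new or still open speak of the compounds shown alone.

Measured so far in a functional assay (spleen, spleen) for activation, with Mus musculus as the target; on this read-out higher numbers stand for an effect only at larger amounts of compound and lower numbers for an effect already at smaller amounts:
- compound 1 `Nc1ncnc2c1nc(O)n2Cc1ccc(Cl)cc1`: 10 uM
- compound 2 `Nc1ncnc2c1nc(Cl)n2Cc1ccccc1`: > 10 uM, a limit
- compound 3 `COc1cccc(Cn2c(O)nc3c(N)ncnc32)c1`: 10 uM

Compound 2 stands only at a limit: its result in this assay, > 10 uM, is a boundary of the measurement and not a number, and (the limit of > 10 uM in this assay, at which 1 of the 3 values shown sits). Compound 4 `Cc1nc2c(N)ncnc2n1Cc1ccccc1` has not been measured; it differs from compound 2 by methyl in place of chloro on an aromatic carbon. Going by the values given here, no two measured compounds differ in a single place, so no measured step is available. Compound 1 gives 10 uM and compound 3 gives 10 uM, so every measured value sits in the same region. Compound 4 is therefore expected to give 10 uM, within 3 uM to 30 uM. The step this estimate implies, a number no higher from compound 2 to compound 4 (the limit leaves the size open), is expected to stay within the usual scatter, with a fair chance that only a limit is reported again.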

Compound 4, minimum effective concentration: > 10 uM
Compound 4: a limit, no number (the forecaster's own chance of this, stated with the estimate: 50%); the middle value sits exactly at the limit.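

Compound 2 and compound 4 both stand only at a limit, so no step can be read between them: the limit of > 10 uM in this assay, at which 2 of the 4 values shown sit.

The compounds shown leave open whether methyl in place of chloro on an aromatic carbon changes the result at all.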